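Cyano Position Shift on the Benzyl Substituent

This account rests on a few compounds, and the source may have more. Where it says the series, first, only, none or still open, it means among the compounds named here.

Measured compounds:
compound 1, `O=C1N(Cc2ccccc2Br)c2cccn2S(=O)(=O)N1Cc1ccccc1`: 226000 nM
compound 2, `N#Cc1ccccc1CN1C(=O)N(Cc2ccccc2)S(=O)(=O)n2cccc21`: > 318000 nM

In an ADME assay on MT4 cells (Homo sapiens) for cytotoxicity, read by MTT assay, with a stated time of 5 days (a higher number here means that more compound is tolerated, a lower number that less compound is tolerated), compound 1 gives 226000 nM. For compound 2 the assay reports only a limit, > 318000 nM, so compound 2 stands at the limit of > 318000 nM in this assay, at which 1 of the 2 values shown sits, and carries no exact number. Among the measured compounds shown here, the single measured step, an at least 1.4-fold higher number from compound 1 to compound 2 (0.14 log units; that floor lies within the scatter), is consequently itself only a bound and does not clearly separate the two compounds.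

Compound 3, `N#Cc1cccc(CN2C(=O)N(Cc3ccccc3)S(=O)(=O)n3cccc32)c1`, differs from compound 2 by 3-cyanophenyl in place of 2-cyanophenyl on a saturated chain carbon bound to an amide-type nitrogen in a ring. For the measured compounds named here, no measured step moves the cyano group to another position on the ring; the one step seen, an at least 1.4-fold higher number from compound 1 to compound 2 (0.14 log units; that floor lies within the scatter), concerns the exchange of bromo for cyano and bears on compound 3 only through the value of compound 2. With nothing pointing in either direction, no step beyond the scatter is expected from compound 2 to compound 3, and compound 3 is expected to sit close to the limit in this assay. The estimate for compound 3 is 300000 nM, with a range from 150000 nM to 600000 nM. This estimate means an expected step of an at least 1.0-fold lower number from compound 2 to compound 3 (0.02 log units; that floor lies within the scatter).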

Compound 3, half-maximal cytotoxic concentration: > 318000 nM
Compound 3 ended at the assay's limit (the forecaster's own chance of this, stated with the estimate: 55%); middle value at least 1.0-fold (0.02 log units) from the limit.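

In this assay, the position of the nitrile on the benzyl group now has a second example, and compound 3 stops at the same limit as compound 2: the limit of > 318000 nM in this assay, at which 2 of the 3 values shown sit. No size can be read for the step between these two compounds, so the change from 2-cyanophenyl to 3-cyanophenyl on the saturated chain carbon shows no measurable effect in either direction. Measured from the bromo compound, the exchange for 3-cyanophenyl gives an at least 1.4-fold higher number from compound 1 to compound 3 (0.14 log units; that floor lies within the scatter), so neither nitrile placement is clearly separated from compound 1.

As far as these compounds go, whether 2-cyanophenyl and 3-cyanophenyl truly differ stays open, as neither has an exact value in this assay. Also open, from the compounds shown here alone, is whether an aminophenyl or a carboxyphenyl group in the same place, on a saturated chain carbon bound to an amide-type nitrogen in a ring, would stay at this limit or give a value clearly lower than those of compound 1, compound 2 and compound 3.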